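Swapping the Pyridyl Ring for a Methylpyrazole

A few compounds are considered here, and "the series" means these few. Any claim that something is new, unique, unknown or untested is made for them only; others in the source may bear on it.

Compound 3 `CN(C)C(=O)C1CCN(c2cnccc2-c2ccccn2)CC1` gives 68 nM in an assay on HEK293F cells for inhibition of cholesterol 24-hydroxylase (Homo sapiens), read by trypan blue exclusion, with stated times of 15 min and 5 h (a lower number here means a stronger inhibitor, a higher number a weaker inhibitor), the lowest of the three numbers; compound 1 `O=C(NC1CC1)c1ccc(-c2cnccc2-c2ccccc2)cc1` gives 74 nM, within the scatter of that, while compound 2 `O=C(NC1CC1)C1CCN(c2cnccc2-c2ccccn2)CC1` gives 160 nM, beyond it. Within the data shown here, the only measured single change is a 2.4-fold lower number from compound 2 to compound 3 (0.37 log units; beyond the scatter). Compound 4 `Cc1ccn(-c2ccncc2N2CCC(C(=O)N(C)C)CC2)n1` differs from compound 3 by 3-methyl-1H-pyrazol-1-yl in place of pyridin-2-yl on an aromatic carbon. Among the measured compounds shown here, no measured step touches this change: compounds 1 and 2 differ in more than one place, and the amide step from compound 2 to compound 3 concerns another part of the molecule, so nothing here speaks for a shift beyond the scatter in either direction. For compound 4 the estimate is therefore 100 nM, with a range of 30 nM to 400 nM. The expected step is a 1.5-fold higher number from compound 3 to compound 4 (0.17 log units; within the scatter).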

Compound 4, half-maximal inhibitory concentration: 1100 nM
Compound 4: middle estimate off by 11-fold (1.04 log units), on the low side; measured number outside the range, above it.
By their numbers in this assay, from the lowest: compounds 3 and 1 (each within the scatter of the next); then compound 2; then compound 4.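

The aromatic carbon opposite the ring nitrogen and ortho to a large group proved sensitive to the aromatic group it carries: in this assay replacing pyridin-2-yl with 3-methyl-1H-pyrazol-1-yl gives a 16-fold higher number from compound 3 to compound 4 (1.21 log units; beyond the scatter) and so costs far more than the change on the amide, a 2.4-fold lower number from compound 2 to compound 3 (0.37 log units; beyond the scatter). Among these compounds, this position therefore does not treat these two aromatic groups of equal heavy-atom count alike, which the earlier compounds could not show. Nothing measured here explains the difference. The compounds shown leave open whether the methyl or the pyrazole ring itself drives the rise, and how an unsubstituted pyrazol-1-yl or a pyrimidin-2-yl would stand on this carbon.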